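Aryl swap on the ring nitrogen: expectation for compound 4

This account rests on a few compounds, and the source may have more. Where it says the series, first, only, none or still open, it means among the compounds named here.

Three measured compounds share one core and differ only in the aryl group on the nitrogen of the five-membered aromatic ring with 3 nitrogen. Compound 1 `N#CC1=C(N)Oc2c(N)cc3nc4ccccc4nc3c2C12C(=O)N(Cc1cnnn1-c1ccc(F)cc1)c1ccccc12` bears 4-fluorophenyl; in a functional assay on A549 cells (Homo sapiens) for antiproliferative activity, read by MTT assay, with a stated time of 48 h (on this read-out lower numbers stand for stronger inhibition and higher numbers for weaker inhibition), compound 1 gives only a limit of the assay, > 50000 nM. Compound 2 `N#CC1=C(N)Oc2c(N)cc3nc4ccccc4nc3c2C12C(=O)N(Cc1cnnn1-c1ccccc1Cl)c1ccccc12` bears 2-chlorophenyl, and in this assay compound 2 gives 29800 nM. Compound 3 `CCOc1ccc(-n2nncc2CN2C(=O)C3(C(C#N)=C(N)Oc4c(N)cc5nc6ccccc6nc5c43)c3ccccc32)cc1` bears 4-ethoxyphenyl; in this assay compound 3 gives only a limit, > 50000 nM. Compound 3 thus stands at the limit of > 50000 nM in this assay, at which 2 of the 3 values shown sit. Of the steps among the three, an at least 1.6-fold lower number from compound 1 to compound 2 (0.22 log units; that floor lies within the scatter) and an at least 1.6-fold higher number from compound 2 to compound 3 (0.22 log units; that floor lies within the scatter) are read only as floors, and a step that the two limits leave unreadable from compound 1 to compound 3 cannot be sized at all.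

Compound 4 `N#CC1=C(N)Oc2c(N)cc3nc4ccccc4nc3c2C12C(=O)N(Cc1cnnn1-c1c(F)cccc1F)c1ccccc12` is not yet measured. It differs from compound 3 by 2,6-difluorophenyl in place of 4-ethoxyphenyl on an aromatic nitrogen. Going by the values given here, no measured step matches this change; the nearest comparisons are the three above, all small or unreadable, and compound 1 with 4-fluorophenyl already sits at the limit. No step beyond the scatter is therefore expected in this assay. Compound 4 is expected at 60000 nM, with a range from 25000 nM to 200000 nM. The expected step is a step that the limit leaves unreadable from compound 3 to compound 4, and the result is most likely reported again as a limit.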

Compound 4, half-maximal inhibitory concentration: > 50000 nM
Compound 4: only a limit was reported (the forecaster's own chance of this, stated with the estimate: 70%); the middle value is on the limit's open side.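

Working notes on the aryl group on the aromatic nitrogen: in this assay, 2,6-difluorophenyl extends the set of aryl groups at this position that end at the assay's limit, and the values now gather there: the limit of > 50000 nM in this assay, at which 3 of the 4 values shown sit.

Going by these compounds alone, the one readable comparison for the new compound is an at least 1.6-fold higher number from compound 2 to compound 4 (0.22 log units; that floor lies within the scatter), so 2,6-difluorophenyl is not separated from 2-chlorophenyl, and compound 2 cannot yet be treated as different from compound 4. The steps from compound 1 and from compound 3 to compound 4 cannot be read, as both ends of each step are limits, so nothing can be said about the size of these changes.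

Within the data shown here, it stays open whether any aryl group at this position moves the read-out beyond the usual scatter, since the series so far offers no value clearly separated from the others. Also open, from the compounds shown here alone, is how the position would read with an aryl group carrying an amine or a carboxylic acid, or with a pyridine ring in place of the phenyl ring.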